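Methyl for chloro on the pyridinone-type core: stability outlook

The compounds below may be only part of what the source reports. "The series", "measured", "known", "first", "only" and "open" are said of these compounds alone.

Measured so far:
- compound 1 `C/C(=C1/OC(=O)NC1=O)C(c1ccc(-c2ccc3cccc(F)c3c2)[nH]c1=O)C(C)C`: in an ADME assay on microsomes from liver (Homo sapiens) for metabolic stability (on this read-out lower numbers stand for a shorter-lived compound and higher numbers for a longer-lived compound), compound 1 gives > 3 h, which is a limit of the assay rather than a number.
- compound 2 `CC(C)C(/C=C1\OC(=O)NC1=O)c1cc(Cl)c(-c2ccc3cccc(F)c3c2)[nH]c1=O`: in this assay compound 2 gives > 3 h, again a limit rather than a number.

Both measured compounds therefore stand at the same place, because of the limit of > 3 h in this assay, at which 2 of the 2 values shown sit. Compound 2 is not separated from compound 1 by any number; both simply sit at the limit, so nothing can be said about an order between them.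

Compound 3 `Cc1cc(C(/C=C2\OC(=O)NC2=O)C(C)C)c(=O)[nH]c1-c1ccc2cccc(F)c2c1` differs from compound 2 in one place: methyl in place of chloro on an aromatic carbon. Chloro leaves and methyl enters, on an aromatic carbon of a six-membered aromatic ring with 1 nitrogen, ortho to a large group.

Among the compounds with values here, no measured step joins the two, so the expectation rests on the two limits alone. In this assay the step is expected to be none beyond the scatter, with a value most likely again reported as a limit. Compound 3 is estimated at 3 h, in the range 1.5 h to 6 h. The expected step of a number no higher from compound 2 to compound 3 (the limit leaves the size open) is essentially flat.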

Compound 3, half-life in the Homo sapiens assay: > 3 h
Compound 3: only a limit was reported; the forecaster's own chance of this, stated with the estimate: 70%; the middle value lies on the limit itself.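

In the Homo sapiens assay no step can be read from compound 2 to compound 3, since both give a limit of the assay and not a number: the limit of > 3 h in the Homo sapiens assay, at which 3 of the 3 values shown sit.

In a physicochemical assay for solubility, measured as kinetic solubility, at pH 2 (a higher number here means a more soluble compound, a lower number a less soluble compound), compound 2 gives 3200 nM and compound 3 gives 39400 nM, a 12-fold higher number from compound 2 to compound 3 (1.09 log units; beyond the scatter).

The compounds shown leave open how long any of them actually lasts in the Homo sapiens assay, and so whether methyl in place of chloro on an aromatic carbon changes that half-life at all.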